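This account rests on a few compounds, and the source may have more. Where it says the series, first, only, none or still open, it means among the compounds named here.

Measured in a functional assay on SK-BR-3 cells (Homo sapiens) for cytotoxicity, read by CellTiter-Glo, with a stated time of 72 h; on this read-out higher numbers stand for weaker inhibition and lower numbers for stronger inhibition:
- compound 1 `C=CCO/N=C1/[C@@H](OC)C[C@H](C)CC2=C(NCCN(C)C)C(=O)C=C(NC(=O)/C(C)=C/C=C\[C@H](OC)[C@@H](OC(N)=O)/C(C)=C/[C@@H]1C)C2=O` gives 400 nM
- compound 2 `CO/N=C1/[C@@H](OC)C[C@H](C)CC2=C(NCCN(C)C)C(=O)C=C(NC(=O)/C(C)=C/C=C\[C@H](OC)[C@@H](OC(N)=O)/C(C)=C/[C@@H]1C)C2=O` gives 550 nM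
- compound 3 `C=CCNC1=C2C[C@@H](C)C[C@H](OC)/C(=N/O)[C@@H](C)/C=C(\C)[C@H](OC(N)=O)[C@@H](OC)/C=C\C=C(/C)C(=O)NC(=CC1=O)C2=O` gives 350 nM

Compound 3 lies within the scatter of both compound 1 and compound 2, so the three values cannot be ranked. Compound 4 `CO[C@H]1C[C@H](C)CC2=C(NCCN(C)C)C(=O)C=C(NC(=O)/C(C)=C/C=C\[C@H](OC)[C@@H](OC(N)=O)/C(C)=C/[C@H](C)/C1=N\O)C2=O` has (dimethylamino)methyl in place of vinyl on a saturated chain carbon bound to an amine nitrogen, which turns allylamino into (2-(dimethylamino)ethyl)amino.

For the measured compounds named here, no measured step makes this change. Going by the values given here, the one measured step is a 1.4-fold higher number from compound 1 to compound 2 (0.14 log units; within the scatter) and concerns another place. Compound 1 and compound 2 already carry the (2-(dimethylamino)ethyl)amino group, and their values lie within the scatter of the value of compound 3. In this assay no step beyond the scatter is therefore expected, and the estimated step is a 1.2-fold higher number from compound 3 to compound 4 (0.08 log units; within the scatter) in size. The estimate for compound 4 is 420 nM (expected range 200 nM to 850 nM).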

Compound 4, half-maximal inhibitory concentration: 95 nM
For compound 4 the middle estimate is 4.4-fold (0.65 log units) above the measured one, outside the stated range (below it).
By their numbers in this assay, from the lowest: compound 4; then compounds 3, 1 and 2 (each within the scatter of the next).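

In this assay (dimethylamino)methyl in place of vinyl on a saturated chain carbon bound to an amine nitrogen gives a 3.7-fold lower number from compound 3 to compound 4 (0.57 log units; beyond the scatter), so this position responds beyond the scatter. With the (2-(dimethylamino)ethyl)amino group kept, hydrogen in place of allyl on the oxygen gives a 4.2-fold lower number from compound 1 to compound 4 (0.62 log units; beyond the scatter) and hydrogen in place of methyl gives a 5.8-fold lower number from compound 2 to compound 4 (0.76 log units; beyond the scatter), although allyl and methyl themselves stayed within the scatter of each other. No measurement shown accounts for these steps.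

The compounds shown leave open whether a longer chain such as 3-(dimethylamino)propyl, or a morpholine at its end, would give a similar step.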